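This account rests on a few compounds, and the source may have more. Where it says the series, first, only, none or still open, it means among the compounds named here.

Measured so far:
Compound 1, `CCOC(=O)c1cccc(-c2ccc(OCC)cc2)c1`: 50000 nM.
Compound 2, `CCOC(=O)c1cccc(-c2ccc(O)cc2)c1`: 100000 nM.
Compound 3, `CCOC(=O)c1cccc(-c2ccc(CN3CCCC3)cc2)c1`: a limit of the assay, > 200000 nM.

In an assay on COS-7 cells for inhibition of patatin-like phospholipase domain-containing protein 2 (Mus musculus) (a lower number here means a stronger inhibitor, a higher number a weaker inhibitor), compound 1 gives 50000 nM, the lowest of the two numbers available. Its nearest neighbour is compound 2, and the step of a 2.0-fold higher number from compound 1 to compound 2 (0.30 log units; within the scatter) is small. Compound 3 sits at the limit of > 200000 nM in this assay, at which 1 of the 3 values shown sits, so it gives no number, and the step of an at least 4.0-fold higher number from compound 1 to compound 3 (0.60 log units; beyond the scatter) is known only as a floor.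

Compound 4, `CCOC(=O)c1cccc(-c2ccc(OCC)c([N+](=O)[O-])c2)c1`, differs from compound 1 by nitro in place of hydrogen on an aromatic carbon: the ethoxy group of compound 1 stays in place, and a nitro group takes the place of a hydrogen on the same aromatic ring. Neither measured step bears on this change directly: the step from compound 1 to compound 2 and the step from compound 1 to compound 3 each replace the ethoxy group itself, whereas compound 4 keeps it. Within the data shown here, with no step of the same kind to lean on, the expected step of no change at the digits printed from compound 1 to compound 4 (within the scatter) is none beyond the scatter. Compound 4 is therefore estimated at 50000 nM, between 15000 nM and 160000 nM.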

Compound 4, half-maximal inhibitory concentration: 200000 nM
Estimate against measurement, compound 4: 4.0-fold (0.60 log units) below; the whole stated range lies below it.
By their numbers in this assay, from the lowest: compounds 1, 2 and 4 (each within the scatter of the next, the first and the last beyond it).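

Compounds 2 and 3 replace the ethoxy group itself, whereas compound 4 keeps it and changes a different carbon of the same ring, ortho to the ethoxy group. In this assay, this change also matters: placing a nitro group there gives a 4.0-fold higher number from compound 1 to compound 4 (0.60 log units; beyond the scatter), so this carbon does not accept nitro without a loss. Compound 4 gives a true number, so this step is read in full, and the only limit among the compounds shown belongs to compound 3: the limit of > 200000 nM in this assay, at which 1 of the 4 values shown sits.

From the compounds shown here alone, it remains open whether the loss is specific to nitro or would also follow from another group at this carbon, such as fluorine, methyl or an amine. Also open, going by these compounds, is whether the nitro step would be the same with hydroxy in place of ethoxy.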